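The source may hold more compounds than are shown below. What is called first, only, known or untested is meant among the compounds shown, and "the series" means these compounds.

In a functional assay on MCF7 cells (Homo sapiens) for antiproliferative activity, read by MTT assay, with stated times of 24 h and 72 h (on this read-out higher numbers stand for weaker inhibition and lower numbers for stronger inhibition), compound 1 `COc1ccc([C@@H]2[C@H](Oc3ccccc3)C(=O)N2c2cc(OC)c(OC)c(OC)c2)cc1OC` gives 26000 nM and compound 2 `COc1cc(N2C(=O)[C@@H](Oc3ccccc3)[C@H]2c2ccc(O)c(O)c2)cc(OC)c1OC` gives 4500 nM on the same read-out. Compound 3 `COc1ccc([C@@H]2[C@H](Oc3ccccc3)C(=O)N2c2cc(OC)c(OC)c(OC)c2)c(N)c1O` at 19000 nM stands level with compound 1 and higher than compound 2. Compound 4 `COc1cc(N2C(=O)[C@@H](Oc3ccccc3)[C@H]2c2cc(N)c(OC)c(O)c2)cc(OC)c1OC` has the same atoms as compound 3, joined differently (a group of 10 heavy atoms (7 carbon, 1 nitrogen, 2 oxygen; one six-membered aromatic ring of carbon only) in place of a group of 10 heavy atoms (7 carbon, 1 nitrogen, 2 oxygen; one six-membered aromatic ring of carbon only), on a saturated ring carbon) on a saturated ring carbon of a four-membered non-aromatic ring with 1 nitrogen. Measured changes at that carbon run from a 1.4-fold lower number from compound 1 to compound 3 (0.14 log units; within the scatter) through a 4.2-fold higher number from compound 2 to compound 3 (0.63 log units; beyond the scatter) to a 5.8-fold lower number from compound 1 to compound 2 (0.76 log units; beyond the scatter) and none rearranges the same atoms, so no step beyond the scatter is expected in this assay for this change. The estimate amounts to an expected 1.6-fold lower number from compound 3 to compound 4 (0.20 log units; within the scatter). Compound 4 is estimated at 12000 nM with a range from 3000 nM to 35000 nM overall.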

Compound 4, half-maximal inhibitory concentration: 8800 nM
Beside the measured number, compound 4's estimate is 1.4-fold (0.13 log units) above it; measured number inside the range.
By their numbers in this assay, from the lowest: compounds 2 and 4 (each within the scatter of the next); then compounds 3 and 1 (each within the scatter of the next).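

In this assay the group on the saturated ring carbon is sensitive to how the same atoms are joined, with a 2.2-fold lower number from compound 3 to compound 4 (0.33 log units; beyond the scatter) lying beyond the scatter. Compound 4 also separates from compound 1, with a 3.0-fold lower number from compound 1 to compound 4 (0.47 log units; beyond the scatter) beyond the scatter. It cannot be told apart from compound 2, however, since a 2.0-fold higher number from compound 2 to compound 4 (0.29 log units; within the scatter) stays within the scatter.

Going by these compounds, whether a carboxylic acid in place of the amino group would hold this level remains open. No evidence at hand explains any of these steps.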